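The compounds below may be only part of what the source reports. "The series", "measured", "known", "first", "only" and "open" are said of these compounds alone.

Measured in a physicochemical assay for solubility, read by nephelometry, measured as kinetic solubility, with a stated time of 30 min; on this read-out higher numbers stand for higher solubility and lower numbers for lower solubility:
compound 1 `CC(C)(O)CN1CCC(Oc2ccc([C@H]3CC[C@]4(CC3)OOC3(O4)C4CC5CC(C4)CC3C5)cc2)CC1`: 1.6 ug/mL
compound 2 `c1cc([C@H]2CC[C@]3(CC2)OOC2(O3)C3CC4CC(C3)CC2C4)ccc1OCCC1CCNCC1`: > 100 ug/mL, which is a limit of the assay rather than a number
compound 3 `c1cc([C@H]2CC[C@]3(CC2)OOC2(O3)C3CC4CC(C3)CC2C4)ccc1OCC1CCNCC1`: 12.5 ug/mL

Compound 1 gives the lowest of the two numbers in this assay; its nearest neighbour is compound 3, and the step of a 7.8-fold higher number from compound 1 to compound 3 (0.89 log units; beyond the scatter) lies beyond the scatter. Compound 2 sits at the limit of > 100 ug/mL in this assay, at which 1 of the 3 values shown sits. The step of an at least 62-fold higher number from compound 1 to compound 2 (1.79 log units; beyond the scatter) can therefore only be read as a lower bound.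

The unmeasured compound is compound 4 `CC(C)(CN)Oc1ccc([C@H]2CC[C@]3(CC2)OOC2(O3)C3CC4CC(C3)CC2C4)cc1`. It differs from compound 1 in one place: 1-(aminomethyl)-1-methylethyl in place of 1-(2-hydroxy-2-methylpropyl)piperidin-4-yl on an oxygen on an aromatic ring. Among the compounds with values here, the change removes the 1-(2-hydroxy-2-methylpropyl)piperidin-4-yl group, which both measured steps from compound 1 also remove, and puts a 1-(aminomethyl)-1-methylethyl group in its place, a group that no measured compound carries. Both measured steps from compound 1 point the same way, an at least 62-fold higher number from compound 1 to compound 2 (1.79 log units; beyond the scatter) and a 7.8-fold higher number from compound 1 to compound 3 (0.89 log units; beyond the scatter), one large and one modest. The step of an at least 8.0-fold lower number from compound 2 to compound 3 (0.90 log units; beyond the scatter) shows that the size of the gain depends on which group enters. For compound 4 a rise beyond the scatter is expected, about a 9.4-fold higher number from compound 1 to compound 4 (0.97 log units; beyond the scatter), nearer the modest step than the large one. Compound 4 is accordingly estimated at 15 ug/mL, with a likely range from 3 ug/mL to 80 ug/mL.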

Compound 4, solubility: > 100 ug/mL
Compound 4: only a limit was reported; the forecaster's own chance of this, stated with the estimate: 15%; middle value at least 6.6-fold (0.82 log units) away from the limit.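

In this assay compound 4 gives > 100 ug/mL, which is a limit of the assay and not a number. On an oxygen on an aromatic ring, 1-(aminomethyl)-1-methylethyl in place of 1-(2-hydroxy-2-methylpropyl)piperidin-4-yl gives an at least 62-fold higher number from compound 1 to compound 4 (1.79 log units; beyond the scatter), and in place of (piperidin-4-yl)methyl it gives an at least 8.0-fold higher number from compound 3 to compound 4 (0.90 log units; beyond the scatter). Every earlier compound carried a six-membered non-aromatic ring in its group at this place, so compound 4 is the first to show that a group with no ring and only 5 heavy atoms can reach the limit already seen for compound 2, though the step from compound 2 to compound 4 cannot be read: the limit of > 100 ug/mL in this assay, at which 2 of the 4 values shown sit.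

The compounds shown leave open how compound 2 and compound 4 stand to each other in this assay, and whether the step follows the amine of the entering group or its short branched chain. They also leave open whether a hydroxyl in place of that amine, or a longer chain carrying it, would give a comparable number at this place.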